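This account rests on a few compounds, and the source may have more. Where it says the series, first, only, none or still open, it means among the compounds named here.

Measured in a functional assay on HT-1080 cells (Homo sapiens) for cytotoxicity, read by MTT assay, with a stated time of 72 h (a higher number here means a weaker inhibitor, a lower number a stronger inhibitor), so far:
compound 1 `COc1ccccc1/C=C1\CCC/C(=C\c2cccc(OC)c2OC)C1=O` gives 14100 nM
compound 2 `COc1ccc(/C=C2\CCC/C(=C\c3cccc(OC)c3OC)C2=O)cc1` gives 16300 nM

Compound 1 and compound 2 lie within the scatter of each other, so neither ranks ahead. Compound 3 `COc1cccc(/C=C2\CCC/C(=C\c3cc(Cl)cc(Cl)c3)C2=O)c1OC` has 3,5-dichlorophenyl in place of 2-methoxyphenyl on a double-bonded chain carbon bound to a double-bonded ring carbon, with the change counted as 3,5-dichlorophenyl in place of 2-methoxyphenyl on a double-bonded chain carbon bound to a double-bonded ring carbon here. For the measured compounds named here, the one measured step at that place is a 1.2-fold higher number from compound 1 to compound 2 (0.06 log units; within the scatter) and it keeps a methoxyphenyl group, while no measured compound carries 3,5-dichlorophenyl. Going by the values given here, with only that small step to go on, the expected change is a 1.4-fold lower number from compound 1 to compound 3 (0.15 log units; within the scatter) in this assay and no step beyond the scatter is expected. Compound 3 is estimated at 10000 nM with 3000 nM to 25000 nM as its expected range.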

Compound 3, half-maximal inhibitory concentration: 6100 nM
Compound 3: the middle estimate sits 1.6-fold (0.21 log units) above what was measured, and the stated range covers the measured number.
By their numbers in this assay, from the lowest: compound 3; then compounds 1 and 2 (each within the scatter of the next).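

In this assay the place on a double-bonded chain carbon bound to a double-bonded ring carbon now responds beyond the scatter: 3,5-dichlorophenyl gives a 2.3-fold lower number from compound 1 to compound 3 (0.36 log units; beyond the scatter) and a 2.7-fold lower number from compound 2 to compound 3 (0.43 log units; beyond the scatter) as modest steps. The two methoxyphenyl compounds alone showed no step beyond the scatter at this place. Nothing at hand accounts for the lower number with 3,5-dichlorophenyl. Open, from the compounds shown here alone, is whether one chlorine alone gives a similar number, and how an amine or a carboxylic acid on that phenyl ring would compare.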